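Amide Tail Swap in a Weak Kinase Inhibitor Series

The source may report more compounds than this note shows. Statements on the series, on what has been measured and on what is new or still open speak of the compounds shown alone.

Measured compounds:
compound 1, `Cn1cc(CNS(=O)(=O)c2ccccc2Nc2cc(-c3ccc4ccn(C)c4c3)c3nccnc3c2)cn1`: in an assay on lysate for inhibition of 6-phosphofructo-2-kinase/fructose-2,6-bisphosphatase 3 (Homo sapiens), with stated times of 0.5 min and 45 min (a lower number here means a stronger inhibitor, a higher number a weaker inhibitor), compound 1 gives > 100000 nM
compound 2, `Cn1cc(CNC(=O)c2ccncc2Nc2cc(-c3ccc4ccn(C)c4c3)c3nccnc3c2)cn1`: in this assay compound 2 gives 75900 nM

The value reported for compound 1 is a limit of this assay and not a number, so the only measured figure is the limit of > 100000 nM in this assay, at which 1 of the 2 values shown sits. Among the compounds with values here, compound 2 therefore stands alone as the single number in this assay, and that number marks it as a weak inhibitor. Within the data shown here, no step between two measured compounds exists to anchor what follows.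

Compound 3, `CC(=O)N1CC(CNC(=O)c2ccncc2Nc2cc(-c3ccc4ccn(C)c4c3)c3nccnc3c2)C1`, is built from compound 2 by a single change: 1-acetylazetidin-3-yl in place of 1-methyl-1H-pyrazol-4-yl on a saturated chain carbon bound to an amide-type nitrogen. The 1-methyl-1H-pyrazol-4-yl of compound 2 sits on a saturated chain carbon bound to an amide-type nitrogen, and in compound 3 the 1-acetylazetidin-3-yl takes its place. Since compound 2 gives 75900 nM and the tail is exchanged far from the shared core, the expected step is a 1.2-fold higher number from compound 2 to compound 3 (0.07 log units; within the scatter). The estimate for compound 3 in this assay is 90000 nM, with a range of 30000 nM to 300000 nM.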

Compound 3, half-maximal inhibitory concentration: > 100000 nM
Compound 3 gave a limit, no number (the forecaster's own chance of this, stated with the estimate: 40%); at least 1.1-fold (0.04 log units) between middle value and limit.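

In this assay compound 3 gives > 100000 nM, which is a limit of the assay and not a number. Exchanging the aromatic 1-methyl-1H-pyrazol-4-yl for the non-aromatic 1-acetylazetidin-3-yl, on a saturated chain carbon bound to an amide-type nitrogen, gives an at least 1.3-fold higher number from compound 2 to compound 3 (0.11 log units; that floor lies within the scatter), so this first step at the position shows that the new tail brought no measurable gain in strength, while the floor of the step does not establish a real loss. With this result, the amide tail position has been tested with two different rings, and the readout has moved to the edge of what the assay reports: the limit of > 100000 nM in this assay, at which 2 of the 3 values shown sit.

The compounds shown leave open how far past its limit compound 3 lies, and with it the true size of the step. They also leave open whether a tail ending in a primary amine or a carboxylic acid, on a saturated chain carbon bound to an amide-type nitrogen, would give a number clearly removed from this weak range.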